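A Single Hydroxy Added to the Methoxyphenyl Group

The source may report more compounds than this note shows. Statements on the series, on what has been measured and on what is new or still open speak of the compounds shown alone.

Of the compounds shown here, three have been tested so far in a functional assay on HeLa cells (Homo sapiens) for antiproliferative activity, read by MTT assay, with a stated time of 48 h (on this read-out higher numbers stand for weaker inhibition and lower numbers for stronger inhibition), and only one of them returned a number. Compound 1 (`COc1ccc(-c2cncc3[nH]c(=O)n(Cc4cc(OC)c(OC)c(OC)c4)c23)cc1`) gives > 20000 nM as a limit of the assay and not a number. Compound 2 (`COc1ccc(-c2nc3cnccc3n2-c2cc(OC)c(OC)c(OC)c2)cc1O`) gives > 20000 nM as a limit as well. Within the data shown here, compound 3 (`COc1ccc(-c2cc3c(cn2)[nH]c(=O)n3-c2cc(OC)c(OC)c(OC)c2)cc1`) gives 1210 nM as the only actual number in the set. Among the measured compounds shown here, no two of these measured compounds differ in just one place, so the data contain no measured step to serve as a guide.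

Compound 4 (`COc1ccc(-c2cc3c(cn2)[nH]c(=O)n3-c2cc(OC)c(OC)c(OC)c2)cc1O`) is compound 3 with one change (hydroxy in place of hydrogen on an aromatic carbon): hydroxy in place of hydrogen on an aromatic carbon, ortho to a methoxy group and meta to a large group. The same difference reads as 4-methoxyphenyl to 3-hydroxy-4-methoxyphenyl.

The expectation therefore starts from compound 3 at 1210 nM and rests on the structural change alone. A moderate move toward stronger inhibition in this assay is expected, probably beyond the scatter but with wide uncertainty. The estimated change is a 3.0-fold lower number from compound 3 to compound 4 (0.48 log units; beyond the scatter) on that reasoning. Compound 4 is estimated at 400 nM (expected range 50 nM to 3000 nM).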

Compound 4, half-maximal inhibitory concentration: 490 nM
For compound 4 the middle estimate is 1.2-fold (0.09 log units) below the measured one; measured number inside the range.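

In this assay, among these compounds, the move to the 3-hydroxy-4-methoxyphenyl group gives a 2.5-fold lower number from compound 3 to compound 4 (0.39 log units; beyond the scatter), the first measured step in this set. It shows that this position, ortho to a methoxy group and meta to a large group, is not a dead end: a single added oxygen atom on this aromatic carbon moves the number in the stronger direction, modestly but beyond the usual scatter, and the compound stays well clear of the assay's limit. This one step carries the whole comparison, because the other compounds shown give limits and not numbers, and they also differ from compound 3 and compound 4 in more than one place: the limit of > 20000 nM in this assay, at which 2 of the 4 values shown sit.

What the compounds shown leave open is whether the gain belongs to the hydroxy itself, since an amine, a fluorine atom or a second methoxy group at the same carbon would be needed to tell that apart. From the compounds shown here alone, it is also open whether the same hydroxy would give a step of similar size on another core, as a limit offers no number from which to read one.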